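Dropping the Carboxy Group on the Sulfur Core

The source may hold more compounds than are shown below. What is called first, only, known or untested is meant among the compounds shown, and "the series" means these compounds.

Compound 1 `CSc1cnc2ccccc2c1[Se]CC#CCOC(=O)c1ccc(C(=O)O)cc1` and compound 2 `CSc1cnc2ccccc2c1[Se]CC#CCOC(=O)c1ccccc1` share one core, while compound 3 `CSc1cnc2ccccc2c1SCC#CCOC(=O)c1ccc(C(=O)O)cc1` and the still unmeasured compound 4 `CSc1cnc2ccccc2c1SCC#CCOC(=O)c1ccccc1` share a second core; how the two cores differ is not broken down here. In a functional assay on B16 cells (Mus musculus) for antiproliferative activity, with a stated time of 72 h (on this read-out lower numbers stand for stronger inhibition and higher numbers for weaker inhibition), compound 1 gives 3.1 ug/mL, and compound 2 gives 2.1 ug/mL. The change from compound 1 to compound 2 is hydrogen in place of carboxy on an aromatic carbon, and it made a 1.5-fold lower number from compound 1 to compound 2 (0.17 log units; within the scatter). On the other core, compound 3 gives 18.1 ug/mL in this assay, the highest of the three numbers; compound 1 is the nearest to it and compound 2 the furthest, and both of those gaps lie beyond the scatter.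

Compound 4 differs from compound 3 by hydrogen in place of carboxy on an aromatic carbon, the same change that was made from compound 1 to compound 2, at a place described in identical words. Since that earlier step stayed within the scatter, the step from compound 3 to compound 4 is expected to be small as well, estimated at a 1.5-fold lower number from compound 3 to compound 4 (0.18 log units; within the scatter). Compound 4 is therefore expected to give 12 ug/mL in this assay, because the same change made a 1.5-fold lower number from compound 1 to compound 2 (0.17 log units; within the scatter). The estimate for compound 4 is expected to lie between 5 ug/mL and 30 ug/mL. A single measured precedent is a thin basis, and the two cores may not respond alike.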

Compound 4, concentration for 50% inhibition: 17.8 ug/mL
For compound 4 the middle estimate is 1.5-fold (0.17 log units) below the measured one, and the stated range covers the measured number.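

For the compounds shown here, on the core of compound 3, the same swap of 4-carboxyphenyl to phenyl made a 1.0-fold lower number from compound 3 to compound 4 (0.01 log units; within the scatter) in this assay, so on this second core, as on the first, removing the carboxy group left no step that can be read above the scatter. Set side by side, the two steps do not differ by more than such steps can be expected to: the same change on two cores in this assay, a 1.5-fold lower number (0.17 log units; within the scatter) from compound 1 to compound 2 and a 1.0-fold lower number (0.01 log units; within the scatter) from compound 3 to compound 4, 1.5-fold (0.16 log units) apart, within the scatter of two such steps. This shows that, on these two cores and in this one read-out, the change carried over as a step too small to resolve; it does not show that the carboxy group has no influence in general, that the same would hold on any further core, or that a step of any particular size transfers, since the comparison rests on just two pairs of compounds.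

From the compounds shown here alone, whether an amine, a methyl ester or a nitrile in place of the carboxy group on the same aromatic ring would also stay within the scatter on both cores remains open. Also open, going by these compounds, is how a longer chain at that place would read in this assay, and whether the two cores would still respond alike to it.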